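Carbamate to urea change at the carbonyl carbon

This account rests on a few compounds, and the source may have more. Where it says the series, first, only, none or still open, it means among the compounds named here.

compound 1 `COC(=O)N(C)CC#CCN1CCCC1` gives 5.5 mg/kg
compound 2 `COC(=O)N(C)CC#CCn1ccnc1` gives 4.5 mg/kg
compound 3 `COC(=O)N(C)CC#CCN(C)C` gives 14.3 mg/kg

In a functional assay on the whole organism for agonist activity, with Mus musculus as the target (on this read-out higher numbers stand for an effect only at larger amounts of compound and lower numbers for an effect already at smaller amounts), compound 1 lies within the scatter of compound 2, and compound 3 carries the highest number of the three. The next entry is compound 4 `CN(C)C(=O)N(C)CC#CCN1CCCC1` and it keeps the core of compound 1. The change is dimethylamino in place of methoxy on a carbonyl carbon and reads as methoxycarbonyl to dimethylcarbamoyl.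

For the measured compounds named here, no measured step touches this carbonyl carbon. All three replace a group on a saturated chain carbon bound to a triple-bonded carbon, so they bear on the change only indirectly and offer a scale rather than a direct precedent. Thus a 1.2-fold lower number from compound 1 to compound 2 (0.09 log units; within the scatter) stays small, while a 2.6-fold higher number from compound 1 to compound 3 (0.41 log units; beyond the scatter) and a 3.2-fold higher number from compound 2 to compound 3 (0.50 log units; beyond the scatter) are modest. The data hold no direct evidence on direction, but compound 1 sits among the lower numbers, so a modest move upward seems the likelier outcome. The expected change in this assay is a 2.2-fold higher number from compound 1 to compound 4 (0.34 log units; beyond the scatter) as a tentative estimate. For compound 4 the estimated value is 12 mg/kg with an expected range from 3.5 mg/kg to 45 mg/kg in this wide first guess.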

Compound 4, dose for half-maximal effect: > 10 mg/kg
Compound 4: a limit, no number; the forecaster's own chance of this, stated with the estimate: 15%; the middle value does not contradict the limit.
By their numbers in this assay, from the lowest: compounds 2 and 1 (each within the scatter of the next); then compound 3.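

Working notes on the carbonyl carbon: this is the first change in the series at this place, since all earlier steps replaced a group on a saturated chain carbon bound to a triple-bonded carbon. In this assay compound 4 carries a limit and not a number: the limit of > 10 mg/kg in this assay, at which 1 of the 4 values shown sits.

The step with dimethylamino in place of methoxy reads as an at least 1.8-fold higher number from compound 1 to compound 4 (0.25 log units; that floor lies within the scatter), so the replacement on the carbonyl carbon shows no sign of moving the read-out towards smaller amounts of compound, yet this floor alone does not separate compound 4 from compound 1.

The compounds shown leave open how far the true number of compound 4 lies past the limit, and with it the real size of the step from methoxycarbonyl to dimethylcarbamoyl. They also leave open how a smaller group such as methylamino or a plain amine would read on this carbonyl carbon, and whether dimethylcarbamoyl would behave alike with the 1H-imidazol-1-yl group of compound 2 or the dimethylamino group of compound 3 on the chain.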